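The compounds below may be only part of what the source reports. "The series", "measured", "known", "first", "only" and "open" are said of these compounds alone.

The measured compounds in a functional assay on HT-29 cells (Homo sapiens) for antiproliferative activity, read by sulforhodamine B assay, with a stated time of 48 h; on this read-out lower numbers stand for stronger inhibition of growth and higher numbers for weaker inhibition of growth:
compound 1 `Cc1ccc(-c2cc(N3CCC(CNS(N)(=O)=O)CC3)ncn2)cc1` gives 33900 nM
compound 2 `CC(C)(C)c1ccc(-c2cc(N3CCC(CNS(N)(=O)=O)CC3)ncn2)cc1` gives 8900 nM

Within the data shown here, compound 2 holds the lowest of the two numbers in this assay; its nearest neighbour is compound 1, and the step of a 3.8-fold lower number from compound 1 to compound 2 (0.58 log units; beyond the scatter) is the only measured step in the set. Compound 3 `COC(=O)c1ccc(-c2cc(N3CCC(CNS(N)(=O)=O)CC3)ncn2)cc1` has not yet been measured. It differs from compound 2 by methoxycarbonyl in place of tert-butyl on an aromatic carbon. Among the measured compounds shown here, no measured pair shows an exchange of this kind: the one measured step concerns the replacement of methyl by tert-butyl at the same place and bears only loosely on the entry of methoxycarbonyl there. With nothing closer to rest on, compound 3 is expected to land between the two measured compounds or somewhat beyond them, the expected step being a 2.2-fold higher number from compound 2 to compound 3 (0.35 log units; beyond the scatter) toward a higher number. The estimate for compound 3 in this assay is 20000 nM, with a range from 5000 nM to 80000 nM.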

Compound 3, concentration for 50% growth inhibition: 22900 nM
Beside the measured number, compound 3's estimate is 1.1-fold (0.06 log units) below it; low and high end bracket the measured number.
By their numbers in this assay, from the lowest: compound 2; then compounds 3 and 1 (each within the scatter of the next).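

In this assay methoxycarbonyl in place of tert-butyl, each a group of 4 heavy atoms with no ring, gives a 2.6-fold higher number from compound 2 to compound 3 (0.41 log units; beyond the scatter) at this aromatic carbon, so the heavy-atom count of the group does not alone set the number here. Methoxycarbonyl in place of methyl gives a 1.5-fold lower number from compound 1 to compound 3 (0.17 log units; within the scatter) and this lies within the scatter, so only tert-butyl stands apart from the other two groups at this place. Nothing available bears on the reason for these results.

The compounds shown leave open whether a carboxylic acid, an amine or a longer alkyl chain at this aromatic carbon would give a number lower than that of compound 2. They also leave open how a single chlorine atom there would compare with tert-butyl.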